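Swapping chloro for methylsulfonyl in an antiproliferative series

A few compounds are considered here, and "the series" means these few. Any claim that something is new, unique, unknown or untested is made for them only; others in the source may bear on it.

Compound 1 `Fc1ccc(C2CC(c3ccc(Cl)s3)=NN2c2nc(-c3ccc(Cl)cc3)cs2)cc1`: 125 ug/mL
Compound 2 `Cc1ccc(-c2csc(N3N=C(c4ccc(C)s4)CC3c3ccc(F)cc3)n2)cc1`: > 500 ug/mL (a limit)

Going by the values given here, in a functional assay on A549 cells (Homo sapiens) for antiproliferative activity, read by XTT assay, with a stated time of 24 h (a lower number here means a stronger inhibitor, a higher number a weaker inhibitor), compound 1 gives 125 ug/mL, the only exact number available so far. Compound 2 gives > 500 ug/mL, which is a limit of the assay and not a number.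

Compound 3 `CS(=O)(=O)c1ccc(-c2csc(N3N=C(c4ccc(Cl)s4)CC3c3ccc(F)cc3)n2)cc1` has not yet been measured. It keeps the core of compound 1 and alters one group: methylsulfonyl in place of chloro on an aromatic carbon. Put simply, methylsulfonyl takes the place of chloro on an aromatic carbon, turning 4-chlorophenyl into 4-(methylsulfonyl)phenyl.

Among the compounds with values here, no pair of measured compounds differs in just one place, so this assay offers no direct guide to the size of this change. The starting point is compound 1 at 125 ug/mL. A modest weakening is expected, meaning a move toward a higher number that may not clear the usual scatter of the assay. The estimated change is a 1.6-fold higher number from compound 1 to compound 3 (0.20 log units; within the scatter). For compound 3 the estimated value is 200 ug/mL, with an expected range of 70 ug/mL to 500 ug/mL.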

Compound 3, half-maximal inhibitory concentration: > 500 ug/mL
Compound 3: no number, only a limit; the forecaster's own chance of this, stated with the estimate: 30%; middle value at least 2.5-fold (0.39 log units) away from the limit.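

In this assay compound 3 gives > 500 ug/mL, which is a limit of the assay and not a number. Going by these compounds alone, this is the first comparison that changes only one place: replacing chloro with methylsulfonyl on the aromatic carbon, turning 4-chlorophenyl into 4-(methylsulfonyl)phenyl while the rest of the structure stays the same, gives an at least 4.0-fold higher number from compound 1 to compound 3 (0.60 log units; beyond the scatter), so activity at this position does depend on the group placed there, and this change loses activity by more than the usual scatter of repeat measurements. The step has only a lower bound and its true size cannot be read, because the result for compound 3 is a limit rather than a measured number: the limit of > 500 ug/mL in this assay, at which 2 of the 3 values shown sit.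

The compounds shown leave open whether chloro is specifically favourable here, or whether other replacements at the same position, such as fluoro, methoxy, an amine or a carboxylic acid, would keep or improve the activity of compound 1. They also leave open how the same swap would behave on a different version of the core, since a single pair cannot show whether this loss of activity holds more widely.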